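This account rests on a few compounds, and the source may have more. Where it says the series, first, only, none or still open, it means among the compounds named here.

In an ADME assay on RAW264.7 cells (Mus musculus) for cytotoxicity, read by WST assay (a lower number here means that less compound is tolerated, a higher number that more compound is tolerated), compound 1, whose structure is `O=C(c1ccc(CN2C(=O)c3ccccc3S2(=O)=O)cc1)N1CCCCC1`, gives 69200 nM. Compound 3, built as `CC(C)(C)OC(=O)N(Cc1ccco1)C(=O)c1ccc(Cn2c(=O)c3ccccc3[s+]2[O-])cc1`, gives 87300 nM in this assay, a number within the scatter of that of compound 1, so the two are not set apart. Compound 2, shown as `O=C(c1ccc(CN2Cc3ccccc3C2=O)cc1)N1CCCCC1`, reaches only a limit of the assay, > 100000 nM, and thus the limit of > 100000 nM in this assay, at which 1 of the 3 values shown sits, applies to it. Among the two numbers given, compound 1 holds the lower one. Compound 4, drawn as `CC(=O)N(Cc1ccco1)C(=O)c1ccc(CN2C(=O)c3ccccc3S2(=O)=O)cc1`, differs from compound 1 in one place: acetyl((furan-2-yl)methyl)amino in place of piperidin-1-yl on a carbonyl carbon. Within the data shown here, no step of this kind has been measured here. The step from compound 1 to compound 4 is expected to stay within the scatter, estimated as a 1.2-fold higher number from compound 1 to compound 4 (0.09 log units; within the scatter). For compound 4 the value in this assay is estimated at 85000 nM, between 45000 nM and 160000 nM.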

Compound 4, concentration lethal to 50% of the cells: > 100000 nM
Compound 4: a limit, no number (the forecaster's own chance of this, stated with the estimate: 30%); at least 1.1-fold (0.07 log units) between middle value and limit.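

Placing acetyl((furan-2-yl)methyl)amino instead of piperidin-1-yl on this carbonyl carbon gives, in this assay, an at least 1.4-fold higher number from compound 1 to compound 4 (0.15 log units; that floor lies within the scatter), so this position takes the change with no drop in the number. For compound 4 the result is a limit, not a number: the limit of > 100000 nM in this assay, at which 2 of the 4 values shown sit. The step is therefore only a floor, and it does not establish a real rise. On these data alone, what remains open is the true size of this step, and whether a primary amine or a carboxylic acid on the same carbonyl carbon would lower the number.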